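Chloro replacing trifluoromethyl on the urea aryl ring

The source may hold more compounds than are shown below. What is called first, only, known or untested is meant among the compounds shown, and "the series" means these compounds.

Three diaryl ureas sharing one core were tested in a functional assay on LOX IMVI cells (Homo sapiens) for inhibition, read by sulforhodamine B assay, with a stated time of 48 h, tested at 10 uM; on this read-out lower numbers stand for a stronger effect and higher numbers for a weaker effect at the one concentration tested. Compound 1 `COc1cc2cc(Oc3ccc(NC(=O)Nc4ccc(C(F)(F)F)cc4)cc3)c(C)nc2cc1OC` gives 56.4%. Compound 2 `COc1cc2cc(Oc3ccc(NC(=O)Nc4cccc(C(F)(F)F)c4)cc3)c(C)nc2cc1OC` gives 9.78%, and compound 3 `COc1cc2cc(Oc3ccc(NC(=O)Nc4ccc(Cl)c(C(F)(F)F)c4)cc3)c(C)nc2cc1OC` gives -81.3%, the lowest of the three numbers. The steps toward it were a number 137.7 percentage points lower from compound 1 to compound 3 (beyond the scatter) and a number 91.1 percentage points lower from compound 2 to compound 3 (beyond the scatter), both large and beyond the scatter, while a number 46.6 percentage points lower from compound 1 to compound 2 (beyond the scatter) was also large.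

Compound 4 `COc1cc2cc(Oc3ccc(NC(=O)Nc4ccc(Cl)c(Cl)c4)cc3)c(C)nc2cc1OC` is now considered. Relative to compound 3 the difference is chloro in place of trifluoromethyl on an aromatic carbon. For the measured compounds named here, no measured pair shows a chloro in place of a trifluoromethyl, so the only guide is indirect. The step from compound 2 to compound 3 shows that a chloro entering on this ring lowered the number strongly; compound 4 keeps that chloro but loses the trifluoromethyl, and the effect of that loss has not been measured here. Some weakening is therefore anticipated, but with wide uncertainty. For compound 4 in this assay the expected result is -45%, within a range from -95% to 15%, which amounts to an expected step of a number 36.3 percentage points higher from compound 3 to compound 4 (beyond the scatter).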

Compound 4, a percentage reported as activity, at one concentration (the size of the read-out at that concentration, not a potency): 23.1%
The estimate for compound 4 lay 68.1 percentage points below the measured number; the measured number lies above the stated range.
By their numbers in this assay, from the lowest: compound 3; then compound 2; then compound 4; then compound 1.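

In this assay, the change from 4-chloro-3-(trifluoromethyl)phenyl to 3,4-dichlorophenyl gives a number 104.4 percentage points higher from compound 3 to compound 4 (beyond the scatter), so at this position chloro does not reproduce the result obtained with trifluoromethyl, even with the other chloro retained. This also qualifies the earlier chloro step: that chloro gave its large shift alongside a trifluoromethyl group, and the 3,4-dichlorophenyl ring falls well short of that result, with a number 13.3 percentage points higher from compound 2 to compound 4 (beyond the scatter), a modest step, against the ring bearing only 3-(trifluoromethyl)phenyl, yet still with a number 33.3 percentage points lower from compound 1 to compound 4 (beyond the scatter), a large step, against the ring bearing 4-(trifluoromethyl)phenyl. The information available gives no independent measurement that would explain the large difference between these two groups.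

The compounds shown leave open how a bromo, methyl or nitrile group would read in the place that trifluoromethyl and chloro have occupied here. They also leave open whether the trifluoromethyl group would give a comparable result with fluoro or methoxy in place of the 4-chloro group on the same ring.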